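A few compounds are considered here, and "the series" means these few. Any claim that something is new, unique, unknown or untested is made for them only; others in the source may bear on it.

Measured in a functional assay on MDA-MB-468 cells (Homo sapiens) for inhibition, read by MTT assay; a lower number here means a stronger inhibitor of growth, a higher number a weaker inhibitor of growth:
- compound 1 `CC1=C(/C=C/C(C)=C/C=C/C(C)=C\C(=O)Nc2ccccc2)C(C)(C)CCC1n1ccnc1` gives 2540 nM
- compound 2 `CC1=C(/C=C/C(C)=C/C=C/C(C)=C\C(=O)Nc2ccc(O)cc2)C(C)(C)CCC1n1ccnc1` gives 6830 nM
- compound 3 `CC1=C(/C=C/C(C)=C/C=C/C(C)=C\C(=O)Nc2cccc(F)c2)C(C)(C)CCC1n1ccnc1` gives 6760 nM

Compound 1, with its unsubstituted phenyl, has the lowest number of the three, and both other compounds lie beyond the scatter from it. Compound 4 `CC1=C(/C=C/C(C)=C/C=C/C(C)=C\C(=O)Nc2ccc(F)cc2)C(C)(C)CCC1n1ccnc1` is still unmeasured. It differs from compound 1 as follows: fluoro in place of hydrogen on an aromatic carbon. This is phenyl to 4-fluorophenyl, with fluoro in place of hydrogen on an aromatic carbon.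

Among the compounds with values here, two measured steps bear on it. The first, a 2.7-fold higher number from compound 1 to compound 3 (0.43 log units; beyond the scatter), brings in the same fluoro, as 3-fluorophenyl. The second, a 2.7-fold higher number from compound 1 to compound 2 (0.43 log units; beyond the scatter), gives 4-hydroxyphenyl, the same substitution pattern with another group. Both are modest and run in the same direction, and a 1.0-fold lower number from compound 2 to compound 3 (0.00 log units; within the scatter) leaves the two substituted compounds level. A modest rise is therefore expected in this assay rather than a large change. The expected step is a 2.2-fold higher number from compound 1 to compound 4 (0.34 log units; beyond the scatter). For compound 4 the estimated value is 5500 nM, with an expected range of 2600 nM to 11000 nM.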

Compound 4, concentration for 50% growth inhibition: 4570 nM
Beside the measured number, compound 4's estimate is 1.2-fold (0.08 log units) above it; measured number inside the range.
By their numbers in this assay, from the lowest: compounds 1, 4, 3 and 2 (each within the scatter of the next, the first and the last beyond it).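

In this assay fluoro in place of hydrogen, para to a large group, stays within the scatter of the unsubstituted phenyl (a 1.8-fold higher number from compound 1 to compound 4 (0.26 log units; within the scatter)), whereas 3-fluorophenyl and 4-hydroxyphenyl each lie beyond it. Moving the fluoro gives no readable separation on these numbers (a 1.5-fold lower number from compound 3 to compound 4 (0.17 log units; within the scatter)). Nor can fluoro be told from hydroxy at this place (a 1.5-fold lower number from compound 2 to compound 4 (0.17 log units; within the scatter)), so the only separations beyond the scatter remain those of the unsubstituted phenyl from 3-fluorophenyl and from 4-hydroxyphenyl.

Going by these compounds, whether an amine, a carboxylic acid or a methoxy group in this place would stay within the scatter of the unsubstituted phenyl remains open. No supporting evidence is available to explain these numbers.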